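Pyrazoline series: methoxy added on the pendant phenyl

The source may hold more compounds than are shown below. What is called first, only, known or untested is meant among the compounds shown, and "the series" means these compounds.

Two members of the series have been measured in a functional assay on A549 cells (Homo sapiens) for antiproliferative activity, read by MTT assay, with a stated time of 24 h; on this read-out higher numbers stand for weaker inhibition and lower numbers for stronger inhibition. Compound 1 `Fc1ccc(C2CC(c3ccccc3)=NN2c2ccc(-c3ccccc3)nn2)cc1` gives 89200 nM in this assay. Compound 2 `COc1cc(C2CC(c3ccccc3)=NN2c2ccc(-c3ccccc3)nn2)cc(OC)c1OC` gives 83800 nM in this assay. Compound 2 holds the lower of the two numbers, but its gap to compound 1 lies within the scatter, so the two compounds are read as equivalent; both sit at the weak end of what this assay resolves.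

Compound 3 `COc1ccc(C2=NN(c3ccc(-c4ccccc4)nn3)C(c3cc(OC)c(OC)c(OC)c3)C2)cc1` has not yet been measured. It differs from compound 2 by methoxy in place of hydrogen on an aromatic carbon; cut one bond further out, the same change reads phenyl to 4-methoxyphenyl. For the measured compounds named here, no measured pair shows this change, so nothing here fixes its size or direction. Given how little separates compound 1 from compound 2 in this assay, the expectation for compound 3 is a step from compound 2 of a 1.2-fold lower number from compound 2 to compound 3 (0.08 log units; within the scatter), not beyond the scatter. The estimate for compound 3 in this assay is 70000 nM, with a range from 30000 nM to 160000 nM.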

Compound 3, half-maximal inhibitory concentration: > 100000 nM
Compound 3 gave a limit, no number (the forecaster's own chance of this, stated with the estimate: 20%); middle value at least 1.4-fold (0.15 log units) away from the limit.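

In this assay compound 3 gives > 100000 nM, which is a limit of the assay and not a number. Methoxy in place of hydrogen on this aromatic carbon, para to a large group, now has its first reading in the series: an at least 1.1-fold higher number from compound 2 to compound 3 (0.07 log units; that floor lies within the scatter). This rules out any lowering of the number by the phenyl to 4-methoxyphenyl change on the background of compound 2, although the floor of the step does not separate the two compounds and its true size remains unknown, with the series now reaching a point where this read-out stops giving a number: the limit of > 100000 nM in this assay, at which 1 of the 3 values shown sits.

Still open, going by these compounds, is whether an amine or a carboxylic acid at this same place would give a number inside the range the assay resolves, or would likewise end at the limit. Also open, on these data alone, is whether methoxy at this place would read the same on a parent with a lower number, where a step in either direction could be sized.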